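The compounds below may be only part of what the source reports. "The series", "measured", "known", "first", "only" and "open" are said of these compounds alone.

Compound 1 `Cn1c(N2N=C(c3ccccc3)CC2c2ccccc2)nc(-c2ccccc2)c(C#N)c1=O` — 35400 nM
Compound 2 `COc1ccc(C2CC(c3ccccc3)=NN2c2nc(-c3ccccc3)c(C#N)c(=O)n2C)cc1` — 18000 nM
Compound 3 `Cn1c(N2N=C(c3ccc(Cl)cc3)CC2c2ccccc2)nc(-c2ccc(Cl)cc2)c(C#N)c1=O` — 25300 nM

All three were tested in a functional assay on MCF7 cells (Homo sapiens) for antiproliferative activity, with a stated time of 72 h; on this read-out lower numbers stand for stronger inhibition and higher numbers for weaker inhibition. In this assay compound 1 gives 35400 nM, compound 2 gives 18000 nM and compound 3 gives 25300 nM. A fourth member of the series, compound 4 `COc1ccc(C2CC(c3ccc(Cl)cc3)=NN2c2nc(-c3ccc(Cl)cc3)c(C#N)c(=O)n2C)cc1`, has not yet been measured.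

Compound 1 and compound 2 differ in a single place: methoxy in place of hydrogen on an aromatic carbon. The step this change made was a 2.0-fold lower number from compound 1 to compound 2 (0.29 log units; within the scatter). Compound 3 is built on a different core than compound 1; the difference between the two cores is not broken down here. Compound 4 relates to compound 3 exactly as compound 2 relates to compound 1: methoxy in place of hydrogen on an aromatic carbon. The surroundings of the change are described in the same words for both pairs, so this is the same change repeated on the second core. The values of compound 3 and compound 1 lie within the scatter of each other, as do those of compound 3 and compound 2.

Within the data shown here, only one earlier instance of this change is available, and it did not move the number beyond the scatter. Among the measured compounds shown here, the step from compound 3 to compound 4 in this assay is expected to be a 1.9-fold lower number from compound 3 to compound 4 (0.29 log units; within the scatter), matching the earlier step because a 2.0-fold lower number from compound 1 to compound 2 (0.29 log units; within the scatter) is the only guide at hand. Compound 4 is therefore estimated at 13000 nM, with a likely range from 6000 nM to 30000 nM.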

Compound 4, half-maximal inhibitory concentration: 27300 nM
Beside the measured number, compound 4's estimate is 2.1-fold (0.32 log units) below it; the range from low to high includes it.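

In this assay, putting methoxy in place of hydrogen on the second core gives a 1.1-fold higher number from compound 3 to compound 4 (0.03 log units; within the scatter), so here too the change stays within the usual scatter of repeated measurements. Set beside the earlier step, the two results cannot be told apart: the same change on two cores in this assay, a 2.0-fold lower number (0.29 log units; within the scatter) from compound 1 to compound 2 and a 1.1-fold higher number (0.03 log units; within the scatter) from compound 3 to compound 4, 2.1-fold (0.33 log units) apart, within the scatter of two such steps. This shows that, in these two pairs, the change from phenyl to 4-methoxyphenyl leaves the number within the scatter on both cores, and nothing here separates how the two cores respond; it does not show that methoxy has a real effect on either core, and with neither step rising above the noise, these pairs cannot prove that an effect carries from one core to the other.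

The compounds shown leave open whether a different group on the same aromatic carbon, such as a hydroxyl group, an amine, a carboxylic acid or a longer chain like butoxy, would move the number beyond the scatter on either core. They also leave open whether the pattern seen in these two pairs would hold on a third core, where one clear step would say more than further steps within the scatter.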